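A few compounds are considered here, and "the series" means these few. Any claim that something is new, unique, unknown or untested is made for them only; others in the source may bear on it.

Measured compounds in an assay on cells for displacement of a labelled ligand from adenosine receptor A2b (Homo sapiens), read by scintillation counting and radioligand binding, with a stated time of 30 min, tested at 10 uM; a higher number here means more inhibition at the concentration tested (going by the name of the read-out), a lower number less inhibition:
compound 1 `Cn1cnc2c(N3CCCCC3)nc(-c3ccccc3O)nc21` — 30.2%
compound 2 `CN1CCN(c2nc(-c3cccc(O)c3)nc3c2ncn3C)CC1` — 47.8%
compound 3 `CN1CCN(c2nc(-c3ccc(Cl)c(Cl)c3)nc3[nH]cnc23)CC1` — 24.1%

Among these three, compound 1 stands second highest in this assay. Its nearest neighbour is compound 3, whose number lies within the usual scatter of that of compound 1, so no order between the two can be claimed; compound 2 sits beyond the scatter above compound 1.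

Compound 4 `Cn1cnc2c(N3CCCCC3)nc(-c3cccc(O)c3O)nc21` is not yet measured. It differs from compound 1 in one place: hydroxy in place of hydrogen on an aromatic carbon. Going by the values given here, no measured pair shows a change of this kind, so nothing in the data tells how large a step to expect. The step from compound 1 to compound 4 is therefore expected to be small, most likely within the scatter, as a number 2.2 percentage points lower from compound 1 to compound 4 (within the scatter). Compound 4 is estimated at 28%, in the range from 10% to 50%.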

Compound 4, a percentage reported as inhibition, at one concentration (the size of the read-out at that concentration, not a potency): 26%
Beside the measured number, compound 4's estimate is 2 percentage points above it; low and high end bracket the measured number.
By their numbers in this assay, from the lowest: compounds 3, 4 and 1 (each within the scatter of the next); then compound 2.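

In this assay, the hydroxy group that turns 2-hydroxyphenyl into 2,3-dihydroxyphenyl gives a number 4.2 percentage points lower from compound 1 to compound 4 (within the scatter). On this aromatic carbon, ortho to a hydroxy group and meta to a large group, the added hydroxy therefore makes no difference that can be told from the scatter. Nothing available explains this result.

The compounds shown leave open whether a methoxy group, a chlorine atom or an amine at this place would also stay within the scatter. They also leave open whether this hydroxy group would give a similar step in compounds other than compound 1.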